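From propoxy to cyclobutyloxy on the shared core

A few compounds are considered here, and "the series" means these few. Any claim that something is new, unique, unknown or untested is made for them only; others in the source may bear on it.

In an ADME assay on the whole organism (Mus musculus, strain CD-1) for pharmacokinetics (a higher number here means faster removal of the compound, a lower number slower removal), compound 1 (`CCOc1cc([C@](O)(CCN(C)C)[C@@H](c2cc3cc(Br)ccc3nc2OC)c2ccnc(OC)c2OC)cc(OC)n1`) gives 9.5 mL/min/kg and compound 2 (`CCCOc1cc([C@](O)(CCN(C)C)[C@@H](c2cc3cc(Br)ccc3nc2OC)c2ccnc(OC)c2OC)cc(OC)n1`) gives 6.9 mL/min/kg, which places compound 2 within the scatter of compound 1. The next structure, compound 3 (`COc1cc([C@](O)(CCN(C)C)[C@@H](c2cc3cc(Br)ccc3nc2OC)c2ccnc(OC)c2OC)cc(OC2CCC2)n1`), carries cyclobutyl in place of propyl on an oxygen on an aromatic ring. Within the data shown here, only one measured step bears on this change, a 1.4-fold lower number from compound 1 to compound 2 (0.14 log units; within the scatter), and it stays within the scatter. No ring has been measured at this place, so no step beyond the scatter is expected. The estimated step is a 1.0-fold higher number from compound 2 to compound 3 (0.01 log units; within the scatter). Compound 3 is expected at 7 mL/min/kg, with an estimated range of 3.5 mL/min/kg to 14 mL/min/kg.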

Compound 3, clearance: 11 mL/min/kg
The estimate for compound 3 lay 1.6-fold (0.20 log units) below the measured number, within the range that was stated.
By their numbers in this assay, from the lowest: compounds 2, 1 and 3 (each within the scatter of the next).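

With cyclobutyl in place of propyl on an oxygen on an aromatic ring, this assay now has a ring at this place, and the result is a 1.6-fold higher number from compound 2 to compound 3 (0.20 log units; within the scatter). With cyclobutyl in place of ethyl, the result is a 1.2-fold higher number from compound 1 to compound 3 (0.06 log units; within the scatter). Ethyl, propyl and cyclobutyl on this oxygen therefore all lie within the scatter of one another, so closing the chain into a ring shows no separable effect here. No evidence bears on why this is so. Going by these compounds, whether a longer chain, a cyclohexyl ring or an amine on this oxygen would also stay within the scatter remains open.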